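Removing a Chloro Group: Expected Effect on Cytotoxicity

The source may report more compounds than this note shows. Statements on the series, on what has been measured and on what is new or still open speak of the compounds shown alone.

Compound 1, `CCN(CC)Cc1ccc2nc(NC(=O)N/N=C/c3cn(Cc4cccc(Cl)c4)c4ccccc34)sc2c1`: in a functional assay on MDA-MB-231 cells (Homo sapiens) for cytotoxicity, read by MTT assay, with a stated time of 72 h (on this read-out higher numbers stand for weaker inhibition and lower numbers for stronger inhibition), compound 1 gives 2050 nM.
Compound 2, `CN(C)Cc1ccc2nc(NC(=O)N/N=C/c3cn(Cc4cccc(Cl)c4)c4ccccc34)sc2c1`: in this assay compound 2 gives 1140 nM.

Within the data shown here, compound 1 stands highest of the two numbers measured so far. Among the measured compounds shown here, its only neighbour is compound 2, and the step of a 1.8-fold lower number from compound 1 to compound 2 (0.25 log units; within the scatter) lies within the scatter, so the two cannot be ordered with confidence. That step changes the amine end of the molecule: dimethylamino in place of diethylamino on a saturated chain carbon bound to an aromatic carbon.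

Compound 3, `CCN(CC)Cc1ccc2nc(NC(=O)N/N=C/c3cn(Cc4ccccc4)c4ccccc34)sc2c1`, differs from compound 1 in another place: hydrogen in place of chloro on an aromatic carbon. The halogen sits on the benzyl ring attached to the indole nitrogen side of the molecule, far from the amine that was varied between compound 1 and compound 2. For the measured compounds named here, no measured step touches this position, so the single step on record does not bear on the change, and that step itself showed nothing beyond the scatter. With no direct evidence, the expectation is no step beyond the scatter in this assay. Compound 3 is therefore expected to give about 2500 nM, in the range 1200 nM to 6000 nM, an expected step of a 1.2-fold higher number from compound 1 to compound 3 (0.09 log units; within the scatter).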

Compound 3, half-maximal inhibitory concentration: 1470 nM
For compound 3 the middle estimate is 1.7-fold (0.23 log units) above the measured one; the range from low to high includes it.
By their numbers in this assay, from the lowest: compounds 2, 3 and 1 (each within the scatter of the next).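

Replacing the chloro of the 3-chlorobenzyl group with hydrogen, which leaves a plain benzyl group, gives a 1.4-fold lower number from compound 1 to compound 3 (0.14 log units; within the scatter) in this assay. Among these compounds, this is the first measured change at this position on the ring, and it shows that compound 1 does not depend on its chlorine atom for the cytotoxicity read here: with hydrogen in that place, the number remains within the usual scatter of repeated measurements. Nothing measured here offers an explanation for this result.

From the compounds shown here alone, this finding rests on a single pair of compounds with the diethylamino group, so it remains open whether the same swap would also stay within the scatter on compound 2, which carries the dimethylamino group. It also remains open what a methoxy group, a trifluoromethyl group or a carboxylic acid would do in the same place on the ring, since chloro and hydrogen are the only two groups shown there, and they give no sign of how far this position would accept something else.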